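Series notes: moving from compound 3 to compound 4

The source may hold more compounds than are shown below. What is called first, only, known or untested is meant among the compounds shown, and "the series" means these compounds.

For the measured compounds named here, compound 3 `CO[C@H]1CC[C@@H](CNc2cc(NCc3cnccc3C(F)(F)F)ncc2C#N)CC1` gives 70 nM in an assay on isolated protein for inhibition of protein kinase C theta type (Homo sapiens), read by TR-FRET, with a stated time of 2 h (a higher number here means a weaker inhibitor, a lower number a stronger inhibitor), the lowest of the three numbers so far. Compound 1 `N#Cc1cnc(NCc2cnccc2C(F)(F)F)cc1N[C@H]1C[C@@H](O)C1` gives 500 nM and compound 2 `N#Cc1cnc(NCc2cnccc2C(F)(F)F)cc1N[C@H]1CC[C@H](O)CC1` gives 350 nM; the gap between these two, a 1.4-fold lower number from compound 1 to compound 2 (0.15 log units; within the scatter), sits within the scatter, whereas a 7.1-fold lower number from compound 1 to compound 3 (0.85 log units; beyond the scatter) and a 5.0-fold lower number from compound 2 to compound 3 (0.70 log units; beyond the scatter) are both beyond it, so compound 3 is the strongest inhibitor measured.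

Compound 4 `CC1(C)C[C@H](Nc2cc(NCc3cnccc3C(F)(F)F)ncc2C#N)CC[C@@H]1O` differs from compound 3 by 4-hydroxy-3,3-dimethylcyclohexyl in place of (4-methoxycyclohexyl)methyl on a nitrogen on an aromatic ring. The nearest measured precedent is compound 2, which carries a hydroxy-substituted cyclohexyl directly on the same nitrogen, and the step of a 5.0-fold lower number from compound 2 to compound 3 (0.70 log units; beyond the scatter) shows how much was gained on the way to compound 3. Compound 4 keeps the hydroxyl of compound 2 but adds two methyl groups to the ring and drops the methylene between ring and nitrogen. The expectation is a number for compound 4 between those of compound 2 and compound 3, that is a modest loss from compound 3, a 2.1-fold higher number from compound 3 to compound 4 (0.33 log units; beyond the scatter). Compound 4 is therefore estimated at 150 nM in this assay, with a range from 50 nM to 500 nM.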

Compound 4, half-maximal inhibitory concentration: 7 nM
Beside the measured number, compound 4's estimate is 21-fold (1.33 log units) above it, and the stated range ends above it.
By their numbers in this assay, from the lowest: compound 4; then compound 3; then compounds 2 and 1 (each within the scatter of the next).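

The hydroxylated ring set directly on the nitrogen had given the two highest numbers, yet with 4-hydroxy-3,3-dimethylcyclohexyl it overtakes the (4-methoxycyclohexyl)methyl group (a 10-fold lower number from compound 3 to compound 4 (1.00 log units; beyond the scatter)), so that longer group is not required for a low number at this position. For the compounds shown here, the 3,3-dimethyl pattern is the only named change between the cyclohexyl groups of compound 2 and compound 4, and it carries the largest gain among the cyclohexyl compounds (a 50-fold lower number from compound 2 to compound 4 (1.70 log units; beyond the scatter)), with the span from the cyclobutyl group wider still (a 71-fold lower number from compound 1 to compound 4 (1.85 log units; beyond the scatter)). Going by these compounds alone, nothing available explains why this change lowers the number so far.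

As far as these compounds go, whether the hydroxyl is needed alongside the 3,3-dimethyl pattern remains open, and an amine in its place would test this. Also open, from the compounds shown here alone, is how the two stereocentres contribute to the result.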